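Benzamide in place of acetamide on the shared pyrazole-bearing core

The source may hold more compounds than are shown below. What is called first, only, known or untested is meant among the compounds shown, and "the series" means these compounds.

Three compounds share one core and differ only in the group carried on an aromatic carbon of that core. Compound 1 `Cc1cc(C(=O)Nc2cccc(F)c2)nn1Cc1cc(Cl)ccc1OCc1ccccc1` gives 200 nM in an assay on CHO-K1 cells for displacement of a labelled ligand from prostaglandin E2 receptor EP1 subtype (Homo sapiens); on this read-out higher numbers stand for weaker inhibition and lower numbers for stronger inhibition. Compound 2 `Cc1cc(C(=O)NCc2ccncc2)nn1Cc1cc(Cl)ccc1OCc1ccccc1` gives 79.4 nM in this assay, and compound 3 `CC(=O)Nc1cc(C)n(Cc2cc(Cl)ccc2OCc2ccccc2)n1` gives 316 nM. Compound 3 thus stands with the highest of the three numbers: the step of a 1.6-fold higher number from compound 1 to compound 3 (0.20 log units; within the scatter) stays within the scatter, while the step of a 4.0-fold higher number from compound 2 to compound 3 (0.60 log units; beyond the scatter) goes beyond it.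

The unmeasured compound 4 `Cc1cc(NC(=O)c2ccccc2)nn1Cc1cc(Cl)ccc1OCc1ccccc1` keeps the acetamido-type arrangement of compound 3 but replaces one group on it: phenyl in place of methyl on a carbonyl carbon, so that acetamido becomes benzamido.

Going by the values given here, no measured step makes this exact change. The two steps that reach compound 3, a 1.6-fold higher number from compound 1 to compound 3 (0.20 log units; within the scatter) and a 4.0-fold higher number from compound 2 to compound 3 (0.60 log units; beyond the scatter), both swap a larger aromatic-containing amide for the small acetamido group, and both move the number upward, one within and one beyond the scatter. Going from acetamido to a larger benzamido is the reverse kind of move, so a modest downward step is expected rather than none. The step of a 2.0-fold lower number from compound 3 to compound 4 (0.30 log units; within the scatter) is the estimated size. Compound 4 is therefore expected to give about 160 nM, in a range from 50 nM to 500 nM.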

Compound 4, half-maximal inhibitory concentration: 15.9 nM
Beside the measured number, compound 4's estimate is 10-fold (1.00 log units) above it; the whole stated range lies above it.
By their numbers in this assay, from the lowest: compound 4; then compound 2; then compounds 1 and 3 (each within the scatter of the next).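

Enlarging the group on the carbonyl carbon matters far more than the earlier comparisons suggested: in this assay, phenyl in place of methyl gives a 20-fold lower number from compound 3 to compound 4 (1.30 log units; beyond the scatter), a large step where the earlier steps were modest or within the scatter. The benzamido group also gives lower numbers than both larger amide groups on the same aromatic carbon, with a 5.0-fold lower number from compound 2 to compound 4 (0.70 log units; beyond the scatter) and a 13-fold lower number from compound 1 to compound 4 (1.10 log units; beyond the scatter), so carrying an aromatic ring does not by itself set the number, as compound 1 also has one. Nothing measured here accounts for the size of this change.

The compounds shown leave open whether the ring on the carbonyl carbon must be aromatic, which a cyclohexyl group there would test, and whether a chlorine or a carboxylic acid on the phenyl ring would keep the number this low. Also open, as far as these compounds go, is what role the amide hydrogen plays, which could be probed by a methyl group on the amide nitrogen of compound 4.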